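Chloro in place of hydrogen on compound 1

This account rests on a few compounds, and the source may have more. Where it says the series, first, only, none or still open, it means among the compounds named here.

In a physicochemical assay for lipophilicity (a higher number here means a more lipophilic compound, a lower number a more polar compound), compound 1 (`O=C(Oc1c(Oc2ccccc2)c(Oc2ccccc2)c(OC(=O)c2ccccc2)c2ccccc12)c1ccccc1`) gives 7.9, the higher of the two measured numbers. Compound 2 (`COc1c(OC)c(OC(C)=O)c2cc(F)ccc2c1OC(C)=O`) gives 2.75, and the gap between them lies well beyond the scatter. Compound 3 (`O=C(Oc1c(Oc2ccccc2)c(Oc2ccccc2)c(OC(=O)c2ccccc2)c2cc(Cl)ccc12)c1ccccc1`) differs from compound 1 by chloro in place of hydrogen on an aromatic carbon. Among the compounds with values here, no measured pair shows this change, so the expectation rests on the structural change alone. A modest rise in this assay, beyond the scatter, is expected, with an estimated step of a number 0.60 log units higher from compound 1 to compound 3 (beyond the scatter). For compound 3 the expected value is 8.5, within an estimated range of 8.1 to 8.9.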

Compound 3, partition coefficient: 8.7
The estimate for compound 3 lay 0.20 log units below the measured number, within the range that was stated.
By their numbers in this assay, from the lowest: compound 2; then compound 1; then compound 3.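

The only pair shown that differs in one place puts chloro in place of hydrogen on an aromatic carbon of the fused system, and it gives a step of a number 0.80 log units higher from compound 1 to compound 3 (beyond the scatter) in this assay. So this position, meta to a fused ring and para to a fused ring, can still move the number upward on a core that already reads high. Nothing shown accounts for the size of this step. Open, as far as these compounds go, is whether another group at this position, such as an amine or a carboxylic acid, would move the number the other way. Also open, from the compounds shown here alone, is whether chloro elsewhere on the core would give a similar step.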